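Swapping the Aryl on the Triazole: What to Expect

The source may report more compounds than this note shows. Statements on the series, on what has been measured and on what is new or still open speak of the compounds shown alone.

Compound 1 `COc1cc2c(cc1CCC(C)C)C(=O)C[C@@H](c1ccc(O)cc1)O2` gives 81% in a functional assay on MCF7 cells (Homo sapiens) for inhibition, read by sulforhodamine B assay, with a stated time of 48 h, tested at 50 uM; a higher number here means more inhibition of growth at the concentration tested, a lower number less inhibition of growth. Compound 2 `COc1ccc([C@@H]2C/C(=N/OCc3cn(-c4ccc(O)cc4)nn3)c3cc(CC=C(C)C)c(OC)cc3O2)cc1` gives 63% in this assay, the lower of the two numbers and below compound 1 by a gap beyond the usual scatter. Compound 3 `COc1ccc([C@@H]2C/C(=N/OCc3cn(-c4cccc(CO)c4)nn3)c3cc(CC=C(C)C)c(OC)cc3O2)cc1` differs from compound 2 by one change: 3-(hydroxymethyl)phenyl in place of 4-hydroxyphenyl on an aromatic nitrogen. Going by the values given here, no measured pair shows what this kind of change does, so the step of a number 3 percentage points lower from compound 2 to compound 3 (within the scatter) is expected to stay within the usual scatter, in no clear direction. Compound 3 is therefore estimated at 60%, with a likely range from 42% to 78%.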

Compound 3, percent growth inhibition at one concentration: 42%
Estimate against measurement, compound 3: 18 percentage points above, and the stated range covers the measured number.
By their numbers in this assay, from the lowest: compound 3; then compound 2; then compound 1.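

In this assay, putting 3-(hydroxymethyl)phenyl in place of 4-hydroxyphenyl on the aromatic nitrogen gives a number 21 percentage points lower from compound 2 to compound 3 (beyond the scatter), so this position responds to the swap even though the counts of hydrogen-bond donors and acceptors stay the same. The change alters where the hydroxyl sits and also adds a carbon, and this one step cannot separate those two differences. Nothing available explains the drop.

Still open, from the compounds shown here alone, is how 3-hydroxyphenyl or 4-(hydroxymethyl)phenyl would compare, which could separate the two differences. Also open, going by these compounds, is what an amine or a carboxylic acid on this aryl ring would do.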